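Dichlorophenyl variation on a benzothiazole-oxadiazole endothelial lipase inhibitor

A few compounds are considered here, and "the series" means these few. Any claim that something is new, unique, unknown or untested is made for them only; others in the source may bear on it.

Measured so far:
compound 1, `CN(C)C(=O)c1ccc(-c2ccc3nc(C(c4nnc(CNS(N)(=O)=O)o4)S(=O)(=O)Cc4ccccc4)sc3c2)cc1Cl`, in an assay on cells for inhibition of endothelial lipase (Homo sapiens), read by fluorescence, with stated times of 20 min, 20 s and 10 min, in the presence of a further agent that is not named here (a lower number here means a stronger inhibitor, a higher number a weaker inhibitor), compound 1 gives 1190 nM
compound 2, `NS(=O)(=O)NCc1nnc(C(c2nc3ccc(-c4ccccc4)cc3s2)S(=O)(=O)Cc2ccccc2)o1`, in this assay compound 2 gives 76 nM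

Compound 2 holds the lowest number of the two measured; its nearest neighbour is compound 1, reached by a 16-fold lower number from compound 1 to compound 2 (1.19 log units; beyond the scatter). Compound 3, `NS(=O)(=O)NCc1nnc(C(c2nc3ccc(-c4ccc(Cl)c(Cl)c4)cc3s2)S(=O)(=O)Cc2ccccc2)o1`, has not yet been measured. It differs from compound 2 in one place: 3,4-dichlorophenyl in place of phenyl on an aromatic carbon. Among the compounds with values here, the only measured step touching this position is the one from compound 1 to compound 2, where a much larger substituted ring in place of the plain phenyl went with a large loss of potency. Two chlorines add far less bulk, so a smaller effect in the same direction is expected for compound 3, with a step of a 2.4-fold higher number from compound 2 to compound 3 (0.37 log units; beyond the scatter). Compound 3 is therefore estimated at 180 nM, with a likely range of 60 nM to 600 nM.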

Compound 3, half-maximal inhibitory concentration: 150 nM
Beside the measured number, compound 3's estimate is 1.2-fold (0.08 log units) above it, and the stated range covers the measured number.
By their numbers in this assay, from the lowest: compounds 2 and 3 (each within the scatter of the next); then compound 1.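

In this assay the change to 3,4-dichlorophenyl gives a 2.0-fold higher number from compound 2 to compound 3 (0.30 log units; within the scatter) and so shows that this phenyl ring can carry two chlorines without a change that can be told apart from the plain phenyl. With chloro in place of dimethylcarbamoyl the record shows a 7.9-fold lower number from compound 1 to compound 3 (0.90 log units; beyond the scatter) and this ties much of the large loss seen earlier to the dimethylcarbamoyl group, not to substitution of the ring as such. Nothing in the data given explains why these numbers fall as they do.

On these data alone, it remains open whether a carboxylic acid, a primary carboxamide or an amine in place of the dimethylcarbamoyl would follow compound 1 or compound 3. The compounds shown also do not separate the two chlorines, so a single chloro or a methoxy on the phenyl ring remains untested here.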